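Amide Nitrogen Substituent Swap in a Sulfonamide Series

This account rests on a few compounds, and the source may have more. Where it says the series, first, only, none or still open, it means among the compounds named here.

For the measured compounds named here, compound 2 `CCN(C(=O)C1CCN(S(=O)(=O)c2ccc3cn[nH]c3c2)CC1)[C@H](C)c1ccccc1` is one of two compounds measured in a functional assay on CHO cells for positive allosteric modulation of muscarinic acetylcholine receptor M5 (Homo sapiens), read by calcium flux (on this read-out higher numbers stand for larger maximal responses and lower numbers for smaller maximal responses), and in this assay compound 2 gives 87%, the lower of the two numbers, though within the scatter of the other. Compound 1 `CCN(C(=O)C1CCN(S(=O)(=O)c2ccc3c(c2)CCO3)CC1)[C@H](C)c1ccccc1` gives in this assay 88%. Going by the values given here, the one measured step, a number 1 percentage points lower from compound 1 to compound 2 (within the scatter), came from exchanging a group on a sulfonyl sulfur and lies within the scatter. Compound 3 `CCN(Cc1ccccc1Cl)C(=O)C1CCN(S(=O)(=O)c2ccc3cn[nH]c3c2)CC1` has not yet been measured in this assay. It differs from compound 2 at a different place: 2-chlorobenzyl in place of 1-phenylethyl on an amide-type nitrogen. Among the compounds with values here, no measured step touches the amide-type nitrogen, so the step seen on the sulfonyl sulfur does not bear directly on this change and gives no direction. With nothing comparable to draw on, the maximal response of compound 3 is expected to stay near that of compound 2, but with a wide range. Compound 3 is therefore estimated at 82%, between 55% and 100%. The step this estimate means, a number 5 percentage points lower from compound 2 to compound 3 (within the scatter), is expected to fall within the scatter.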

Compound 3, largest response reached (reported as percent of maximum), in percent of the reference or control that the assay uses: 93%
Beside the measured number, compound 3's estimate is 11 percentage points below it; the range from low to high includes it.
By their numbers in this assay, from the lowest: compounds 2, 1 and 3 (each within the scatter of the next).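

The amide-type nitrogen had not been touched by the earlier comparison, and here the exchange gives, in this assay, a number 6 percentage points higher from compound 2 to compound 3 (within the scatter). At this position, then, 2-chlorobenzyl can stand in place of 1-phenylethyl without the maximal response moving outside the scatter, even though the swap brings in a chlorine and removes the defined stereocentre of the leaving group. No independent measurement is available that would account for this result.

The single step changes several things at once, so the compounds shown leave open whether the chlorine, the loss of the branching methyl or the loss of the stereocentre matters on its own; an unsubstituted benzyl group on the same nitrogen would separate these features. They also leave open how far this position reaches beyond groups carrying a six-membered aromatic ring of carbon only, for instance with a cyclohexylmethyl or a pyridylmethyl group, and whether the ethyl group on the same nitrogen could give way to a longer chain.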